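The compounds below may be only part of what the source reports. "The series", "measured", "known", "first", "only" and "open" are said of these compounds alone.

Measured compounds in this series:

compound 1 `Clc1ccc(-c2cc(-c3ccsc3)nc(-c3ccccc3Cl)c2)o1`: 0%
compound 2 `Clc1ccc(-c2cc(-c3cccs3)nc(-c3ccccc3Cl)c2)o1`: 41.3%
compound 3 `Clc1ccc(-c2cc(-c3ccoc3)cc(-c3cccs3)n2)cc1`: 0%

In an assay on isolated protein for inhibition of DNA topoisomerase 1 (Homo sapiens), tested at 100 uM (on this read-out lower numbers stand for a weaker effect and higher numbers for a stronger effect at the one concentration tested), compound 2 gives 41.3%. Compound 1 gives 0% in this assay, and the change thiophen-3-yl in place of thiophen-2-yl on an aromatic carbon is tied to a step of a number 41.3 percentage points lower from compound 2 to compound 1 (beyond the scatter), a drop beyond the scatter. Compound 3 gives 0% in this assay, level with compound 1 at the digits recorded; the two sit together at the lowest of the three numbers. The difference between the core of compound 2 and the core of compound 3 is not broken down here.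

Compound 4 `Clc1ccc(-c2cc(-c3ccoc3)cc(-c3ccsc3)n2)cc1` is not yet measured. It differs from compound 3 by thiophen-3-yl in place of thiophen-2-yl on an aromatic carbon. This is the same kind of change as from compound 2 to compound 1, but the surroundings are not identical: in the earlier pair the changed position is meta to a 2-chlorophenyl group and meta to a 5-chlorofuran-2-yl group, whereas here it is meta to a 4-chlorophenyl group and meta to a furan-3-yl group.

The earlier step lowered the read-out, yet compound 3 already sits at the bottom of the recorded range, so a downward step of comparable size has no room to show. The step from compound 3 to compound 4 in this assay is expected to be about a number 3 percentage points higher from compound 3 to compound 4 (within the scatter), resting on compound 3 giving 0%. Compound 4 is therefore estimated at 3%, between 0% and 15%.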

Compound 4, a percentage reported as inhibition, at one concentration (the size of the read-out at that concentration, not a potency): 0%
Beside the measured number, compound 4's estimate is 3 percentage points above it, and the stated range covers the measured number.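

In this assay, thiophen-3-yl in place of thiophen-2-yl on an aromatic carbon next to the ring nitrogen shows no change at the digits printed from compound 3 to compound 4 (within the scatter). Set beside the earlier case, the size of this change does not carry from one core to the other: the same change on two cores in this assay, a number 41.3 percentage points lower (beyond the scatter) from compound 2 to compound 1 and no change at the digits printed (within the scatter) from compound 3 to compound 4, 41.3 percentage points apart, beyond the scatter of two such steps

This does not show that the core of compound 3 would tolerate the change on a higher baseline, since compound 3 already gives 0%, the lowest number recorded in this series, and a fall on this core could not appear.

Still open, going by these compounds, is whether thiophen-2-yl would again give the higher number on another core that starts above the bottom of the range, and which of the features that separate the core of compound 2 from the core of compound 3 accounts for the gap between them. Also open, on these data alone, is what an amine or a carboxylic acid in place of the chlorine, or a longer chain in place of the furan-3-yl group, would do in this assay.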